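Chloro for trifluoromethyl on the urea aryl of compound 3

This account rests on a few compounds, and the source may have more. Where it says the series, first, only, none or still open, it means among the compounds named here.

Measured compounds: compound 1 `COc1cc(Cl)cc(-c2nn(-c3cccc(NC(=O)c4ccc(Cl)c(Cl)c4)c3)cc2-c2ccncc2)c1` gives 53.4%; compound 2 `O=C(Nc1cccc(-n2cc(-c3ccncc3)c(-c3cc(O)cc(Cl)c3)n2)c1)Nc1ccc(Cl)c(Cl)c1` gives -47.4%; compound 3 `COc1cc(Cl)cc(-c2nn(-c3cccc(NC(=O)Nc4ccc(Cl)c(C(F)(F)F)c4)c3)cc2-c2ccncc2)c1` gives -22.6%, all in a functional assay on OVCAR-3 cells (Homo sapiens) for inhibition, read by sulforhodamine B assay, with a stated time of 48 h, tested at 10 uM; on this read-out higher numbers stand for a weaker effect at the one concentration tested and lower numbers for a stronger effect.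

Compound 3 stands second highest of the three numbers; compound 2 lies below it beyond the scatter, compound 1 above it beyond the scatter. Compound 4 `COc1cc(Cl)cc(-c2nn(-c3cccc(NC(=O)Nc4ccc(Cl)c(Cl)c4)c3)cc2-c2ccncc2)c1` differs from compound 3 by chloro in place of trifluoromethyl on an aromatic carbon. Within the data shown here, the one measured step nearby, a number 76 percentage points lower from compound 1 to compound 3 (beyond the scatter), changed two things at once and so bears only loosely on this change. Compound 2 carries the same dichlorophenyl urea and shows a lower number than compound 3. Compound 4 is therefore expected to sit near compound 3 or somewhat lower, as a number 7.4 percentage points lower from compound 3 to compound 4 (within the scatter), giving an estimated -30% with a range from -60% to 5%.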

Compound 4, a percentage reported as activity, at one concentration (the size of the read-out at that concentration, not a potency): 4.11%
Compound 4: the middle estimate sits 34.1 percentage points below what was measured; the range from low to high includes it.
By their numbers in this assay, from the lowest: compound 2; then compound 3; then compound 4; then compound 1.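

Chloro in place of trifluoromethyl on this aromatic carbon, ortho to a chloro group, is not an interchangeable swap in this assay: it gives a number 26.7 percentage points higher from compound 3 to compound 4 (beyond the scatter) and so a weaker effect at the one concentration tested. With the 3,4-dichlorophenyl group held constant, the urea in place of the amide gives a number 49.3 percentage points lower from compound 1 to compound 4 (beyond the scatter) and methyl in place of hydrogen on the oxygen gives a number 51.5 percentage points higher from compound 2 to compound 4 (beyond the scatter). No evidence given here accounts for these steps. Going by these compounds, how a nitrile or a methyl would read on this carbon stays open, as does whether trifluoromethyl gives the same step alongside a hydroxyl group.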